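Triazolylmethyl spirooxindole series: aryl swap on the triazole nitrogen

A few compounds are considered here, and "the series" means these few. Any claim that something is new, unique, unknown or untested is made for them only; others in the source may bear on it.

Measured compounds in a functional assay on HepG2 cells (Homo sapiens) for antiproliferative activity, read by MTT assay, with a stated time of 48 h; a higher number here means a weaker inhibitor, a lower number a stronger inhibitor:
- compound 1 `N#CC1=C(N)Oc2c(N)cc3nc4ccccc4nc3c2C12C(=O)N(Cc1cnnn1-c1ccc(F)cc1)c1ccccc12`: > 50000 nM, a limit of the assay
- compound 2 `CCOc1ccc(-n2nncc2CN2C(=O)C3(C(C#N)=C(N)Oc4c(N)cc5nc6ccccc6nc5c43)c3ccccc32)cc1`: > 50000 nM, a limit of the assay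
- compound 3 `CCc1cccc(C)c1-n1nncc1CN1C(=O)C2(C(C#N)=C(N)Oc3c(N)cc4nc5ccccc5nc4c32)c2ccccc21`: > 50000 nM, a limit of the assay

Compound 3 thus stands at the limit of > 50000 nM in this assay, at which 3 of the 3 values shown sit; no number separates it from the other two. The three steps among the measured compounds are all unreadable: a step that the two limits leave unreadable from compound 1 to compound 2, a step that the two limits leave unreadable from compound 1 to compound 3 and a step that the two limits leave unreadable from compound 2 to compound 3. The shared core is kept throughout; only the aryl group on the triazole nitrogen changes.

Compound 4 `N#CC1=C(N)Oc2c(N)cc3nc4ccccc4nc3c2C12C(=O)N(Cc1cnnn1-c1ccc(F)c(Cl)c1)c1ccccc12` is the next member, and its change from compound 3 is 3-chloro-4-fluorophenyl in place of 2-ethyl-6-methylphenyl on an aromatic nitrogen. Going by the values given here, the steps that bear on this change, from compound 1 and from compound 2 to compound 3, both vary the same aryl group and both ended at the limit, so their size is unknown. Among the compounds with values here, no measured step gives a direction. Compound 4 is therefore expected to remain at the limit as well, with a small chance of a readable number. The step this estimate means, a step that the limit leaves unreadable from compound 3 to compound 4, is expected to lie within the scatter. Compound 4 is estimated at 80000 nM, with a range from 20000 nM to 300000 nM.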

Compound 4, half-maximal inhibitory concentration: > 50000 nM
Compound 4: no number, only a limit (the forecaster's own chance of this, stated with the estimate: 85%); the middle value is on the limit's open side.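

In this assay compound 4 gives > 50000 nM, a limit of the assay. No step among compound 1, compound 2, compound 3 and compound 4 can be read, because all four share one limit: the limit of > 50000 nM in this assay, at which 4 of the 4 values shown sit.

The compounds shown leave open whether any aryl group on the triazole nitrogen of the shared core gives a readable number in this assay.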